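A 2,4-dimethylphenyl group replaces 4-aminophenyl

This account rests on a few compounds, and the source may have more. Where it says the series, first, only, none or still open, it means among the compounds named here.

In a functional assay on A549 cells (Homo sapiens) for antiproliferative activity, read by MTT assay, with a stated time of 48 h (on this read-out higher numbers stand for weaker inhibition and lower numbers for stronger inhibition), compound 1 `CCCC(C)Oc1ccc(C(=O)/C=C/c2c(/C=C/c3ccc(OC)cc3)cc(OC)cc2OC)cc1` gives 9.4 ug/mL, compound 2 `COc1ccc(/C=C/c2cc(OC)cc(OC)c2/C=C/C(=O)c2ccc(C)cc2)cc1` gives 3.6 ug/mL and compound 3 `COc1ccc(/C=C/c2cc(OC)cc(OC)c2/C=C/C(=O)c2ccc(N)cc2)cc1` gives 3.8 ug/mL. Compound 3 thus stands level with compound 2, and both lie under compound 1. Compound 4 `COc1ccc(/C=C/c2cc(OC)cc(OC)c2/C=C/C(=O)c2ccc(C)cc2C)cc1` has 2,4-dimethylphenyl in place of 4-aminophenyl on a carbonyl carbon. The closest evidence is a 1.1-fold higher number from compound 2 to compound 3 (0.02 log units; within the scatter), which is within the scatter. The larger 2.6-fold lower number from compound 1 to compound 2 (0.42 log units; beyond the scatter) and a 2.5-fold lower number from compound 1 to compound 3 (0.39 log units; beyond the scatter) both removed 1-methylbutoxy, a group absent from this change. Among the compounds with values here, no measured compound carries 2,4-dimethylphenyl, so that remains untested. In this assay the expected change is no change at the digits printed from compound 3 to compound 4 (within the scatter), so no step beyond the scatter is expected. Compound 4 is estimated at 3.8 ug/mL, with an expected range from 1.9 ug/mL to 8 ug/mL.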

Compound 4, half-maximal inhibitory concentration: 0.3 ug/mL
Compound 4: the middle estimate sits 13-fold (1.10 log units) above what was measured; the measured number lies below the stated range.
By their numbers in this assay, from the lowest: compound 4; then compounds 2 and 3 (each within the scatter of the next); then compound 1.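

In this assay, methyl in place of hydrogen on an aromatic carbon gives a 12-fold lower number from compound 2 to compound 4 (1.08 log units; beyond the scatter), although amino in place of methyl had made no change beyond the scatter. Within the data shown here, the 2,4-dimethylphenyl group gives a 13-fold lower number from compound 3 to compound 4 (1.10 log units; beyond the scatter) against 4-aminophenyl and a 31-fold lower number from compound 1 to compound 4 (1.50 log units; beyond the scatter) against 4-(1-methylbutoxy)phenyl, so the group on this carbonyl carbon can shift the number much further than the earlier compounds showed. Nothing given here explains this gain. As far as these compounds go, whether an ethyl group in place of the added methyl, or a chlorine or methoxy group, would give a similar step remains open.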